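Methoxy for Hydrogen on the Aryl Ring: Expected Potency of Compound 4

The source may hold more compounds than are shown below. What is called first, only, known or untested is meant among the compounds shown, and "the series" means these compounds.

Compound 1 `COC(=O)/C(=C/c1ccccc1)CN1C(=O)[C@@H](OC)[C@H]1c1ccc(Cl)cc1` gives 15300 nM in a functional assay on MCF7 cells (Homo sapiens) for antiproliferative activity, read by MTT assay, with a stated time of 48 h; a higher number here means a weaker inhibitor, a lower number a stronger inhibitor.
Compound 2 `COC(=O)/C(=C/c1ccccc1)CN1C(=O)[C@@H](OC)[C@H]1c1cccc(C(F)(F)F)c1` gives no result reported in this assay.
Compound 3 `COC(=O)/C(=C/c1ccccc1)CN1C(=O)[C@@H](OC)[C@H]1c1ccccc1` gives 12900 nM in this assay.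

Among the compounds with values here, compound 3 carries the lowest of the two numbers, yet the single measured step on this ring, a 1.2-fold lower number from compound 1 to compound 3 (0.07 log units; within the scatter), lies within the scatter, so the two compounds cannot be ranked. Compound 4 `COC(=O)/C(=C/c1ccccc1)CN1C(=O)[C@@H](OC)[C@H]1c1ccc(OC)cc1` differs from compound 3 by methoxy in place of hydrogen on an aromatic carbon. Within the data shown here, no measured step involves a methoxy group, and the only substitution change on this ring left this assay essentially unmoved. Compound 4 is therefore expected to show a step of a 1.1-fold lower number from compound 3 to compound 4 (0.03 log units; within the scatter), not beyond the scatter. Compound 4 is estimated at 12000 nM, within a range of 5000 nM to 30000 nM.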

Compound 4, half-maximal inhibitory concentration: 11600 nM
Compound 4: the middle estimate sits 1.0-fold (0.01 log units) above what was measured; measured number inside the range.
By their numbers in this assay, from the lowest: compounds 4, 3 and 1 (each within the scatter of the next).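

Methoxy brings a group with a hydrogen-bond acceptor to this position on the aromatic ring, and in this assay it gives a 1.1-fold lower number from compound 3 to compound 4 (0.05 log units; within the scatter) and a 1.3-fold lower number from compound 1 to compound 4 (0.12 log units; within the scatter). Hydrogen, chloro and methoxy at this position therefore cannot be told apart in this assay, so the earlier finding for chloro and hydrogen now extends to a third group. Nothing available bears on why these compounds read alike. The compounds shown leave open whether an amine or a carboxylic acid here, or a longer chain in place of methoxy, would give a number beyond the scatter of these three.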